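Chlorine Added to the Phenyl, Carried Across Two Cores

The source may report more compounds than this note shows. Statements on the series, on what has been measured and on what is new or still open speak of the compounds shown alone.

Measured compounds:
Compound 1, `Oc1ccc(O)c(-c2cc(-c3ccccc3)nn2-c2ccccc2)c1`, 22600 nM
Compound 2, `Oc1ccc(O)c(-c2cc(-c3ccc(Cl)cc3)nn2-c2ccccc2)c1`, 8790 nM
Compound 3, `NS(=O)(=O)c1ccc(-n2nc(-c3ccccc3)cc2-c2cc(O)ccc2O)cc1`, 61900 nM

Of the compounds shown here, three have been measured in a functional assay on cells (Melanoma cell, Homo sapiens) for cytotoxicity, read by sulforhodamine B assay, with a stated time of 48 h; a higher number here means a weaker inhibitor of growth, a lower number a stronger inhibitor of growth. Compound 1 gives 22600 nM. Compound 2 differs from it by chloro in place of hydrogen on an aromatic carbon, and this change gave a 2.6-fold lower number from compound 1 to compound 2 (0.41 log units; beyond the scatter). Compound 3 differs from compound 1 by sulfamoyl in place of hydrogen on an aromatic carbon, and that change gave a 2.7-fold higher number from compound 1 to compound 3 (0.44 log units; beyond the scatter), so compound 3 has the highest number of the three; its values next to compound 2 show the widest gap of the set.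

Compound 4, `NS(=O)(=O)c1ccc(-n2nc(-c3ccc(Cl)cc3)cc2-c2cc(O)ccc2O)cc1`, has not yet been measured. It differs from compound 3 by chloro in place of hydrogen on an aromatic carbon. For the measured compounds named here, this is the same change as the one from compound 1 to compound 2: the chloro enters at the same kind of place in both pairs. What differs between the two cores is the sulfamoyl on compound 3, given by sulfamoyl in place of hydrogen on an aromatic carbon above.

The expectation for compound 4 rests on the step from compound 1 to compound 2, a 2.6-fold lower number from compound 1 to compound 2 (0.41 log units; beyond the scatter), applied to the value of compound 3, 61900 nM. Compound 4 is therefore expected to show a step of a 2.5-fold lower number from compound 3 to compound 4 (0.39 log units; beyond the scatter) in this assay. Whether the chloro step repeats in size on the sulfamoyl core cannot be checked from the measured compounds, so the range is kept wide. Compound 4 is estimated at 25000 nM, between 11000 nM and 55000 nM.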

Compound 4, concentration for 50% growth inhibition: 14600 nM
Estimate against measurement, compound 4: 1.7-fold (0.23 log units) above; low and high end bracket the measured number.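

In this assay, the chloro change carried over to the sulfamoyl core, where it gave a 4.2-fold lower number from compound 3 to compound 4 (0.63 log units; beyond the scatter), and the two chloro steps do not differ from each other by more than the scatter allows: the same change on two cores in this assay, a 2.6-fold lower number (0.41 log units; beyond the scatter) from compound 1 to compound 2 and a 4.2-fold lower number (0.63 log units; beyond the scatter) from compound 3 to compound 4, 1.6-fold (0.22 log units) apart, within the scatter of two such steps. Read the other way round, the sulfamoyl change on the chlorinated core gave a 1.7-fold higher number from compound 2 to compound 4 (0.22 log units; within the scatter), so this step lies within the scatter while its counterpart on the core of compound 1 does not, yet the two steps still cannot be told apart: the same change on two cores in this assay, a 2.7-fold higher number (0.44 log units; beyond the scatter) from compound 1 to compound 3 and a 1.7-fold higher number (0.22 log units; within the scatter) from compound 2 to compound 4, 1.6-fold (0.22 log units) apart, within the scatter of two such steps. This shows that the phenyl to 4-chlorophenyl change behaved alike on these two cores in this one assay, but it does not show that the change would carry to any further core, it gives no reason for the agreement, and the larger size of the step on the sulfamoyl core cannot be taken as a real difference.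

The compounds shown leave open whether a group other than chloro at the same place, such as a methoxy, a trifluoromethyl or an amine, would carry from one core to the other in the same way. They also leave open whether a carboxylic acid in place of the sulfamoyl would give steps of a similar size.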